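The source may report more compounds than this note shows. Statements on the series, on what has been measured and on what is new or still open speak of the compounds shown alone.

Compound 2 `Cc1nc(NCc2ccsc2)nc(N[C@@H]2C[C@H](CO)[C@@H](O)[C@H]2O)c1-c1nc2ccccc2s1` is the weaker of the two measured compounds in an ADME assay on the whole organism (plasma) for pharmacokinetics, with Rattus norvegicus as the target, with a stated time of 6 h, at a dose of 10 mg/kg by the oral route; on this read-out higher numbers stand for higher exposure at the dose given and lower numbers for lower exposure: compound 2 gives 96.7 ng.h/mL, whereas compound 1 `Cc1nc(NCC(C)C)nc(N[C@@H]2C[C@H](CO)[C@@H](O)[C@H]2O)c1-c1nc2ccccc2s1` gives 1020 ng.h/mL. Within the data shown here, the only measured step, an 11-fold lower number from compound 1 to compound 2 (1.02 log units; beyond the scatter), shows that swapping a small branched alkyl group for an aromatic ring on that side chain costs a great deal of exposure.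

Compound 3 `Cc1nc(NCc2ccncc2)nc(N[C@@H]2C[C@H](CO)[C@@H](O)[C@H]2O)c1-c1nc2ccccc2s1` differs from compound 2 in one place: pyridin-4-yl in place of thiophen-3-yl on a saturated chain carbon bound to a nitrogen on an aromatic ring. Both rings are aromatic and both bring one hydrogen-bond acceptor, so this is a change between two aromatic rings rather than a return to the alkyl group of compound 1. Among the measured compounds shown here, the one known step therefore does not bear directly on it: it tells what alkyl against aromatic does, not what one aromatic ring against another does. No comparison between two aromatic rings is available here.

With nothing to point firmly either way, the step of a 1.4-fold higher number from compound 2 to compound 3 (0.16 log units; within the scatter) is expected to stay within the usual scatter. Compound 3 is expected to give about 140 ng.h/mL in this assay, with a likely range from 40 ng.h/mL to 500 ng.h/mL.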

Compound 3, area under the concentration-time curve: 47.9 ng.h/mL
Compound 3: middle estimate off by 2.9-fold (0.47 log units), on the high side; the measured number falls inside the stated range.
By their numbers in this assay, from the lowest: compound 3; then compound 2; then compound 1.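

The choice between two aromatic rings matters at this position: in this assay, the modest step of a 2.0-fold lower number from compound 2 to compound 3 (0.31 log units; beyond the scatter) shows that pyridin-4-yl in place of thiophen-3-yl on the saturated chain carbon changes exposure beyond the usual scatter. The large step of a 21-fold lower number from compound 1 to compound 3 (1.33 log units; beyond the scatter) shows that a second aromatic ring also falls far short of the isopropyl group, and among these three compounds, most of the drop goes with leaving isopropyl rather than with which of the two rings enters. No supporting measurement is available to explain why exposure differs among these compounds.

The compounds shown leave open whether reaching exposure close to that of compound 1 depends on a branched alkyl group, or whether a cyclopropyl group or a longer straight alkyl chain in the same place would serve as well. They also leave open how a plain phenyl ring would compare with thiophen-3-yl and pyridin-4-yl, which would help separate the effect of the aromatic ring itself from that of its hetero atom.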